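A few compounds are considered here, and "the series" means these few. Any claim that something is new, unique, unknown or untested is made for them only; others in the source may bear on it.

Measured compounds:
Compound 1, `COc1ccc(/C=C/C2CC(=O)C=CO2)cc1OC`: 86.9 uM
Compound 2, `COc1cc(/C=C/C2CC(=O)C=CO2)cc(OC)c1OC`: 102 uM
Compound 3, `COc1cc(/C=C/C2CC=CC(=O)O2)cc(OC)c1`: 8.1 uM

In a functional assay on U-251 cells (Homo sapiens) for inhibition, read by sulforhodamine B assay, with a stated time of 48 h (on this read-out higher numbers stand for weaker inhibition of growth and lower numbers for stronger inhibition of growth), compound 1 gives 86.9 uM and compound 2 gives 102 uM. The change between them is methoxy in place of hydrogen on an aromatic carbon, and it gave a 1.2-fold higher number from compound 1 to compound 2 (0.07 log units; within the scatter). Compound 3 gives 8.1 uM in this assay; how its core differs from that of compound 1 is not broken down here. Compound 4, `COc1cc(/C=C/C2CC=CC(=O)O2)cc(OC)c1OC`, is not yet measured. It differs from compound 3 by methoxy in place of hydrogen on an aromatic carbon, the same kind of change as from compound 1 to compound 2, though here the entering group sits ortho to two methoxy groups and para to a group of 9 heavy atoms, rather than ortho to one methoxy group and meta to the other and to the larger group. Because a 1.2-fold higher number from compound 1 to compound 2 (0.07 log units; within the scatter) lay within the scatter, the step of a 1.2-fold higher number from compound 3 to compound 4 (0.07 log units; within the scatter) is expected to be small as well. Compound 4 is estimated at 9.5 uM, between 4 uM and 22 uM.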

Compound 4, concentration for growth inhibition (reported as GI): 25.1 uM
The estimate for compound 4 lay 2.6-fold (0.42 log units) below the measured number; measured number outside the range, above it.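

In this assay, the methoxy in place of hydrogen gave a 3.1-fold higher number from compound 3 to compound 4 (0.49 log units; beyond the scatter), while the change of core with the aromatic ring held fixed gave a 4.1-fold lower number from compound 2 to compound 4 (0.61 log units; beyond the scatter). Set side by side, the two methoxy steps cannot be told apart: the same change on two cores in this assay, a 1.2-fold higher number (0.07 log units; within the scatter) from compound 1 to compound 2 and a 3.1-fold higher number (0.49 log units; beyond the scatter) from compound 3 to compound 4, 2.6-fold (0.42 log units) apart, within the scatter of two such steps. This gives no sign that the change acts differently on the two cores, but two pairs do not prove that it carries over, and they say nothing about any third core.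

The compounds shown carry only methoxy groups on the aromatic ring, leaving open how a hydroxyl, a chlorine or an amine there would read. Also open, on these data alone, is the effect of a saturated chain in place of the double-bonded chain carbons.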